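Triazole for tetrazole on the sulfur-linked chain

The source may hold more compounds than are shown below. What is called first, only, known or untested is meant among the compounds shown, and "the series" means these compounds.

The three measured compounds share one core and differ only in the group carried on the sulfur-linked chain, or in the ring fused to it. In an assay on CHO cells for displacement of a labelled ligand from adenosine receptor A1 (Homo sapiens), read by scintillation counting, with a stated time of 90 min, tested at 1 uM (a higher number here means more inhibition at the concentration tested (going by the name of the read-out), a lower number less inhibition), compound 1 `N#Cc1c(N)nc(SCC(N)=O)c(C#N)c1-c1ccc(OCC2CC2)cc1` gives 31%. In this assay compound 2 `N#Cc1c(N)nc2sc(C(N)=O)c(N)c2c1-c1ccc(OCC2CC2)cc1` gives 19%. In this assay compound 3 `N#Cc1c(N)nc(SCc2nnn[nH]2)c(C#N)c1-c1ccc(OCC2CC2)cc1` gives 3%, the lowest of the three numbers, beyond the scatter below both compound 2 and compound 1. Among the measured compounds shown here, the only single-change step available is a number 28 percentage points lower from compound 1 to compound 3 (beyond the scatter); compound 2 is not joined to compound 3 by one change, so its number is only a reference point.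

Compound 4 `N#Cc1c(N)nc(SCn2cncn2)c(C#N)c1-c1ccc(OCC2CC2)cc1` differs from compound 3 as follows: 1H-1,2,4-triazol-1-yl in place of 1H-tetrazol-5-yl on a saturated chain carbon bound to a sulfur. The step from compound 1 to compound 3 bears on this only indirectly: it shows that exchanging the group on the saturated chain carbon bound to a sulfur can move the number well beyond the scatter, but it gives no reading for 1H-1,2,4-triazol-1-yl itself. Since compound 3 already sits at the bottom of the series, the room downward is small. Compound 4 is therefore expected to give about 10%, within 0% to 28%, which means an expected step of a number 7 percentage points higher from compound 3 to compound 4 (within the scatter), not beyond the scatter.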

Compound 4, a percentage reported as inhibition, at one concentration (the size of the read-out at that concentration, not a potency): 12%
Estimate against measurement, compound 4: 2 percentage points below, and the stated range covers the measured number.
By their numbers in this assay, from the lowest: compounds 3, 4 and 2 (each within the scatter of the next, the first and the last beyond it); then compound 1.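

In this assay, 1H-1,2,4-triazol-1-yl in place of 1H-tetrazol-5-yl on a saturated chain carbon bound to a sulfur gives a number 9 percentage points higher from compound 3 to compound 4 (within the scatter), so this exchange does not separate the two rings, although 1H-tetrazol-5-yl carries a hydrogen-bond donor and 1H-1,2,4-triazol-1-yl carries none. Set against carbamoyl, the triazole gives a number 19 percentage points lower from compound 1 to compound 4 (beyond the scatter), and with a number 28 percentage points lower from compound 1 to compound 3 (beyond the scatter) this places both five-membered aromatic rings shown beyond the scatter below carbamoyl at this position. No available evidence bears on the reason for these steps.

Open, going by these compounds, is whether a carboxylic acid, a primary amine or a longer chain ending in carbamoyl on this carbon would read at or above the level of compound 1. Each reading also comes from a single concentration, so the potency of these compounds remains undefined.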